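The compounds below may be only part of what the source reports. "The series", "measured", "known", "first", "only" and "open" are said of these compounds alone.

In an ADME assay on MT4 cells (Homo sapiens) for cytotoxicity, read by MTT assay (a lower number here means that less compound is tolerated, a higher number that more compound is tolerated), compound 1 (`O=C(CSc1nncnc1-c1cccc2ccccc12)Nc1ccc(Cl)cc1Cl`) gives 254000 nM, compound 2 (`O=C(CSc1nncnc1-c1ccccc1Cl)c1ccc(Br)cc1Br`) gives 28000 nM and compound 3 (`CC(=O)c1ccc(NC(=O)CSc2nncnc2-c2ccccc2Cl)c(Br)c1`) gives 34000 nM. Compound 2 and compound 3 thus lie within the scatter of each other, while compound 1 stands beyond the scatter above compound 2. Compound 4 (`O=C(CSc1nncnc1-c1ccccc1Cl)Nc1ccccc1F`) departs from compound 2 in one place, with (2-fluorophenyl)amino in place of 2,4-dibromophenyl on a carbonyl carbon. Within the data shown here, no measured pair shows this change alone, so the expectation is loose. A moderate rise in this assay is expected, resting on compound 3 at 34000 nM and compound 1 at 254000 nM, which like compound 4 carry an amide hydrogen. The estimated move is a 2.1-fold higher number from compound 2 to compound 4 (0.33 log units; beyond the scatter). Compound 4 is expected at 60000 nM, within an estimated range of 25000 nM to 150000 nM.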

Compound 4, half-maximal cytotoxic concentration: 98000 nM
Estimate against measurement, compound 4: 1.6-fold (0.21 log units) below; low and high end bracket the measured number.
By their numbers in this assay, from the lowest: compounds 2 and 3 (each within the scatter of the next); then compound 4; then compound 1.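

In this assay, among these compounds, the carbonyl carbon whose other neighbour is a saturated chain carbon proves responsive to what it carries: (2-fluorophenyl)amino in place of 2,4-dibromophenyl gives a 3.5-fold higher number from compound 2 to compound 4 (0.54 log units; beyond the scatter), the first step here that changes one place only. The swap removes both bromines and adds the nitrogen, its hydrogen-bond donor and the fluorine all at once, so the step cannot be assigned to any one of them. No measurement bearing on a cause is available.

From the compounds shown here alone, whether (2,4-dibromophenyl)amino on this carbon would stand with compound 2 or with compound 4 remains open. So does the result of a methoxy group or a carboxylic acid on the phenyl ring.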